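The source may hold more compounds than are shown below. What is called first, only, known or untested is meant among the compounds shown, and "the series" means these compounds.

Measured compounds in a functional assay on MCF7 cells (Homo sapiens) for antiproliferative activity, read by MTT assay; a lower number here means a stronger inhibitor, a higher number a weaker inhibitor:
compound 1 `c1ccc2c(c1)ccn2-c1nc(N2CCCCC2)nc2ccccc12` gives 50 ug/mL
compound 2 `Cn1cc(-c2nc(N3CCNCC3)nc3ccccc23)c2ccccc21` gives 50 ug/mL
compound 3 `CN1CCN(c2nc(-n3ccc4ccccc43)c3ccccc3n2)CC1` gives 6 ug/mL

Among the measured compounds shown here, compound 3 stands lowest of the three numbers; both compound 1 and compound 2 sit well above it, with the one measured step being an 8.3-fold lower number from compound 1 to compound 3 (0.92 log units; beyond the scatter). Compound 2 carries an unsubstituted piperazine and a differently attached indole, so it differs from compound 3 in more than one place; its value and that of compound 3 can only be set side by side.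

Compound 4 `Fc1ccc(N2CCN(c3nc(-n4ccc5ccccc54)c4ccccc4n3)CC2)cc1` is not yet measured. It differs from compound 3 as follows: 4-fluorophenyl in place of methyl on an amine nitrogen in a ring. For the measured compounds named here, no measured step touches this position: the only known step changes the whole ring attached to the core, not a group on the piperazine nitrogen. So there is no direct basis for a direction; the series is too thin to expect a move beyond the scatter with any confidence. A number near compound 3 is the neutral expectation, with a wide range to cover the uncertainty, the step being estimated as a 2.0-fold higher number from compound 3 to compound 4 (0.30 log units; within the scatter). Compound 4 is therefore estimated at 12 ug/mL, range 3 ug/mL to 50 ug/mL.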

Compound 4, half-maximal inhibitory concentration: 50 ug/mL
Compound 4: middle estimate off by 4.2-fold (0.62 log units), on the low side; the range from low to high includes it.
By their numbers in this assay, from the lowest: compound 3; then compounds 1, 2 and 4 (each within the scatter of the next).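

In this assay, the amine nitrogen of the piperazine ring responds to its substituent: exchanging methyl for 4-fluorophenyl gives an 8.3-fold higher number from compound 3 to compound 4 (0.92 log units; beyond the scatter). The earlier step changed the whole ring on the core, whereas this one leaves that ring in place and alters only the group on its nitrogen, so the number of compound 3 depends on that group as well as on the ring itself. Nothing available explains this rise.

With only methyl and 4-fluorophenyl on this nitrogen among the compounds shown, it stays open whether the higher number follows the aromatic ring, the fluorine or simply the larger group. Ethyl, benzyl or unsubstituted phenyl at the same place would help to separate these readings.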